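Replacing the group on the aromatic nitrogen of compound 1

The source may hold more compounds than are shown below. What is called first, only, known or untested is meant among the compounds shown, and "the series" means these compounds.

Measured in an ADME assay on HOS cells (Homo sapiens) for cytotoxicity; a higher number here means that more compound is tolerated, a lower number that less compound is tolerated:
- compound 1 `CN1CCC(n2c(CN(C)C3CCCc4cccnc43)nc3ccccc32)CC1`: 16000 nM
- compound 2 `CN1CCCC(Cn2c(CN(C)C3CCCc4cccnc43)nc3ccccc32)C1`: 3000 nM
- compound 3 `CN(Cc1nc2ccccc2n1C[C@H]1CCCN(Cc2cccnc2)C1)[C@H]1CCCc2cccnc21`: 2500 nM

Compound 1 has the highest number of these three. Compound 4 `CN(Cc1nc2ccccc2n1CC1CNC1)C1CCCc2cccnc21` has not yet been measured. It carries (azetidin-3-yl)methyl in place of 1-methylpiperidin-4-yl on an aromatic nitrogen. Among the measured compounds shown here, one measured step bears directly on this change at the same place, a modest one: a 5.3-fold lower number from compound 1 to compound 2 (0.73 log units; beyond the scatter). There, too, a group ending in methyl replaced 1-methylpiperidin-4-yl. For the measured compounds named here, no measured compound has a four-membered ring, so this guide is only partial. A lower number is still expected, probably by less than that step. The expected step is a 2.3-fold lower number from compound 1 to compound 4 (0.36 log units; beyond the scatter). Compound 4 is estimated at 7000 nM, with an expected range of 2500 nM to 20000 nM.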

Compound 4, half-maximal cytotoxic concentration: 15000 nM
For compound 4 the middle estimate is 2.1-fold (0.33 log units) below the measured one; measured number inside the range.
By their numbers in this assay, from the lowest: compounds 3 and 2 (each within the scatter of the next); then compounds 4 and 1 (each within the scatter of the next).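

In this assay the change to (azetidin-3-yl)methyl gives a 1.1-fold lower number from compound 1 to compound 4 (0.03 log units; within the scatter) and so does not carry the drop seen with compound 2, which means that replacing 1-methylpiperidin-4-yl does not by itself lower the number. With the saturated chain carbon kept, azetidin-3-yl in place of 1-methylpiperidin-3-yl gives a 5.0-fold higher number from compound 2 to compound 4 (0.70 log units; beyond the scatter) and shows that the group on that carbon matters. Nothing measured here explains this difference.

Compound 2 and compound 4 differ in both ring size and the methyl on the ring nitrogen. The group (1-methylazetidin-3-yl)methyl would help separate these two changes.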